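This account rests on a few compounds, and the source may have more. Where it says the series, first, only, none or still open, it means among the compounds named here.

Of the compounds shown here, two have so far been measured in an assay on isolated protein for binding affinity to Leucine-rich repeat serine/threonine-protein kinase 2 variant G2019S (Homo sapiens), read by TR-FRET and LanthaScreen, with a stated time of 2 h; a higher number here means a weaker inhibitor, a lower number a stronger inhibitor. Compound 1 `Cc1c(Nc2nc(N)c3c(C#N)c(N4CCC[C@H]4C)n(C)c3n2)cnn1C` gives 3 nM, while compound 2 `C[C@@H]1CCCN1c1c(C#N)c2c(N)nc(Nc3ccn(C)n3)cc2n1C` gives 13 nM. Compound 1 therefore has the lower of the two numbers, and its gap to compound 2 lies beyond the usual scatter. Compound 3 `C[C@@H]1CCCN1c1c(C#N)c2c(N)nc(Nc3cnn(C)c3)nc2n1C` has not yet been measured. It differs from compound 1 by hydrogen in place of methyl on an aromatic carbon. Within the data shown here, no measured pair shows this particular change. A modest weakening is nonetheless expected, and the estimated step is a 2.0-fold higher number from compound 1 to compound 3 (0.30 log units; within the scatter). Compound 3 is thus expected to give about 6 nM, plausibly between 2 nM and 20 nM.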

Compound 3, inhibition constant: 0.3 nM
Estimate against measurement, compound 3: 20-fold (1.30 log units) above; the measured number lies below the stated range.
By their numbers in this assay, from the lowest: compound 3; then compound 1; then compound 2.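

Going from 1,5-dimethyl-1H-pyrazol-4-yl to 1-methyl-1H-pyrazol-4-yl gives, in this assay, a 10-fold lower number from compound 1 to compound 3 (1.00 log units; beyond the scatter), the first reading of any change at this position. This methyl is therefore not needed for a low number here, and its removal gives a clear gain. Nothing available explains the size of this step.

Only hydrogen and methyl are shown on this aromatic carbon, so what an ethyl group, a fluorine or an amine would give there stays open. A single step also cannot tell whether this change would act the same way on another core.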